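Swapping methoxy for nitro on an aromatic carbon

The source may report more compounds than this note shows. Statements on the series, on what has been measured and on what is new or still open speak of the compounds shown alone.

- compound 1 `Cc1ccc(/C=C2\SC(=O)N(CCNC(=O)Nc3c(C)n(C)n(-c4ccccc4)c3=O)C2=O)cc1`: 22400 nM
- compound 2 `COc1ccc(/C=C2\SC(=O)N(CCNC(=O)Nc3c(C)n(C)n(-c4ccccc4)c3=O)C2=O)cc1`: 6180 nM

Going by the values given here, in a functional assay on HeLa cells (Homo sapiens) for inhibition, read by MTT assay, with a stated time of 48 h (on this read-out lower numbers stand for stronger inhibition and higher numbers for weaker inhibition), compound 2, at 6180 nM, holds the lower of the two numbers measured so far. Compound 3 `Cc1c(NC(=O)NCCN2C(=O)S/C(=C\c3ccc([N+](=O)[O-])cc3)C2=O)c(=O)n(-c2ccccc2)n1C` keeps the rest of compound 2 and changes one group: nitro in place of methoxy on an aromatic carbon. In short, this puts nitro in place of methoxy on an aromatic carbon, para to a large group.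

Among the compounds with values here, only one measured step bears on this: a 3.6-fold lower number from compound 1 to compound 2 (0.56 log units; beyond the scatter). That step put methoxy in place of methyl on an aromatic carbon, and it was modest. It says nothing directly about nitro, so the direction is uncertain. Leaving methoxy, the group of compound 2 at 6180 nM, a modest rise in this assay is expected. The expected change is a 1.6-fold higher number from compound 2 to compound 3 (0.21 log units; within the scatter). For compound 3 the estimated value is 10000 nM, with an expected range from 2500 nM to 35000 nM.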

Compound 3, half-maximal inhibitory concentration: 37700 nM
Compound 3: middle estimate off by 3.8-fold (0.58 log units), on the low side, and the stated range ends below it.
By their numbers in this assay, from the lowest: compound 2; then compounds 1 and 3 (each within the scatter of the next).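

In this assay, this position, para to a large group on the aromatic ring, responds clearly to the group placed there: nitro in place of methoxy undoes the advantage that methoxy had over methyl (a 6.1-fold higher number from compound 2 to compound 3 (0.79 log units; beyond the scatter)). Nitro and methyl, by contrast, cannot be told apart at this position (a 1.7-fold higher number from compound 1 to compound 3 (0.23 log units; within the scatter)). Among these three groups, methoxy alone stands apart from the other two, so a lower number here is tied to that one group, a pattern that rests on these three compounds only.

Nothing in the data at hand explains why methoxy differs from the other two groups. On these data alone, whether a hydroxyl, an amine or a longer ether such as ethoxy at this position would match methoxy, or fall with methyl and nitro, remains open.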